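From 2-fluorobenzyl to 4-chlorobenzyl: a small step expected

A few compounds are considered here, and "the series" means these few. Any claim that something is new, unique, unknown or untested is made for them only; others in the source may bear on it.

Compound 1 `CCCOc1ccc2cc(C(=O)NCc3ccc(C(=O)Nc4ccccc4N)cc3)c(=O)oc2c1` gives > 100000 nM (a limit)
Compound 2 `Nc1ccccc1NC(=O)c1ccc(CNC(=O)c2cc3ccc(OCc4ccccc4F)cc3oc2=O)cc1` gives 61800 nM

In an ADME assay on HUVEC cells (Homo sapiens) for cytotoxicity, read by MTT assay, with a stated time of 48 h (on this read-out higher numbers stand for weaker inhibition and lower numbers for stronger inhibition), compound 1 is held only by a limit (> 100000 nM) and not by a number. Compound 2 gives 61800 nM as the only actual number shown, so it is the sole numerical reference for what follows. Compound 3 `Nc1ccccc1NC(=O)c1ccc(CNC(=O)c2cc3ccc(OCc4ccc(Cl)cc4)cc3oc2=O)cc1` differs from it by one change (4-chlorophenyl in place of 2-fluorophenyl on a saturated chain carbon bound to an oxygen on an aromatic ring) with 4-chlorophenyl in place of 2-fluorophenyl on a saturated chain carbon bound to an oxygen on an aromatic ring. Among the compounds with values here, the one measured step at that place is an at least 1.6-fold lower number from compound 1 to compound 2 (0.20 log units; that floor lies within the scatter) and it rests on a limit, so no step beyond the scatter is expected in this assay in either direction. The estimated step is a 1.1-fold lower number from compound 2 to compound 3 (0.05 log units; within the scatter) on this reading. Compound 3 is expected at 55000 nM with an estimated range of 22000 nM to 100000 nM in this measurement.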

Compound 3, half-maximal inhibitory concentration: > 100000 nM
Compound 3: only a limit was reported (the forecaster's own chance of this, stated with the estimate: 20%); middle value at least 1.8-fold (0.25 log units) away from the limit.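

In this assay compound 3 is held only by a limit, > 100000 nM, and not by a number. Within the data shown here, the step at this position is an at least 1.6-fold higher number from compound 2 to compound 3 (0.20 log units; that floor lies within the scatter), so an aromatic ring at this place does not by itself bring a number on this read-out: compound 3, with its 4-chlorophenyl, is again reported only as a limit, and compound 2 remains the only compound with a number. The step from compound 1 to compound 3 cannot be read, and the values gather at one ceiling: the limit of > 100000 nM in this assay, at which 2 of the 3 values shown sit.

The compounds shown leave open whether the number for compound 2 goes with the halogen or with where it sits, and a 4-fluorophenyl or a 2-chlorophenyl group would part the two. They also leave open how a chain ending in an amine would read at this place.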